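Hydroxamate linker swapped from alkyl chain to pyrimidine

A few compounds are considered here, and "the series" means these few. Any claim that something is new, unique, unknown or untested is made for them only; others in the source may bear on it.

Of the compounds shown here, three sharing one core have been tested in a functional assay on MCF7 cells (Homo sapiens) for antiproliferative activity, read by CCK-8 assay, with a stated time of 72 h; on this read-out higher numbers stand for weaker inhibition and lower numbers for stronger inhibition. Compound 1 `CCOc1cc(C(C)(C)C)ccc1C1=NC(c2ccc(Cl)cc2)C(c2ccc(Cl)cc2)N1C(=O)NCCCCC(=O)Nc1ccccc1N` gives 29100 nM. Within the data shown here, compound 2 `CCOc1cc(C(C)(C)C)ccc1C1=NC(c2ccc(Cl)cc2)C(c2ccc(Cl)cc2)N1C(=O)NCCCCCCCC(=O)NO` gives 7920 nM; the one measured step, a 3.7-fold lower number from compound 1 to compound 2 (0.57 log units; beyond the scatter), is the only change that ends at a hydroxamate. Compound 3 `CCOc1cc(C(C)(C)C)ccc1C1=NC(c2ccc(Cl)cc2)C(c2ccc(Cl)cc2)N1C(=O)N1CCN(CCCCC(=O)NO)CC1` gives 9800 nM, the second highest of the three numbers: its value and that of compound 2 lie within the scatter of each other, while the value of compound 1 is higher, beyond the scatter.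

Compound 4 `CCOc1cc(C(C)(C)C)ccc1C1=NC(c2ccc(Cl)cc2)C(c2ccc(Cl)cc2)N1C(=O)N1CCN(c2ncc(C(=O)NO)cn2)CC1` differs from compound 3 by 5-(hydroxycarbamoyl)pyrimidin-2-yl in place of 4-(hydroxycarbamoyl)butyl on an amine nitrogen in a ring. Among the measured compounds shown here, no measured step swaps a saturated chain for an aromatic ring while keeping the hydroxamate, so the step from compound 1 to compound 2 bears only loosely on it; the two hydroxamates measured so far sit close together regardless of how the hydroxamate is attached. Compound 4 is therefore expected to show a 1.2-fold lower number from compound 3 to compound 4 (0.09 log units; within the scatter), a step not clearly beyond the scatter. Compound 4 is estimated at 8000 nM, within 2500 nM to 25000 nM.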

Compound 4, half-maximal inhibitory concentration: 3460 nM
Compound 4: middle estimate off by 2.3-fold (0.36 log units), on the high side, and the stated range covers the measured number.
By their numbers in this assay, from the lowest: compound 4; then compounds 2 and 3 (each within the scatter of the next); then compound 1.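

In this assay, the change on the amine nitrogen in the ring gives a 2.8-fold lower number from compound 3 to compound 4 (0.45 log units; beyond the scatter). This is the first step shown in which the hydroxamate stays in place and only its attachment changes, and it shows that the number at this position responds to that attachment: 5-(hydroxycarbamoyl)pyrimidin-2-yl, with its six-membered aromatic ring, replaces the ring-free 4-(hydroxycarbamoyl)butyl. Nothing available explains the modest gain.

The compounds shown leave open whether the aromatic ring itself or its two ring nitrogens account for the step, which a phenyl ring bearing the same hydroxamate would help to separate. They also leave open whether a longer chain on this nitrogen would match the pyrimidine, and whether a carboxylic acid could stand in for the hydroxamate here.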